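Moving the chlorine around the benzyl ring on the sulfur

This account rests on a few compounds, and the source may have more. Where it says the series, first, only, none or still open, it means among the compounds named here.

In a functional assay on the whole organism (artery, strain albino) with Rattus norvegicus as the target, with a stated time of 720 min, at a dose of 10 mg/kg by the oral route (a higher number here means more inhibition at the dose given (going by the name of the read-out), a lower number less inhibition), compound 1 `COc1ccc(C2N=C(SCc3ccccc3Cl)NC(C)=C2C(=O)Nc2ccc(F)cc2)cc1OC` gives 23.2%. Among the compounds with values here, its only measured neighbour is compound 2 `COc1ccc(C2N=C(SCc3cccc(Cl)c3)NC(C)=C2C(=O)Nc2ccc(F)cc2)cc1OC`, which in this assay gives 15.5%; the two values lie within the scatter of each other, as the step of a number 7.7 percentage points lower from compound 1 to compound 2 (within the scatter) shows. Compound 3 `COc1ccc(C2N=C(SCc3ccc(Cl)cc3)NC(C)=C2C(=O)Nc2ccc(F)cc2)cc1OC` has not yet been measured in this assay. It differs from compound 1 in a single place: 4-chlorophenyl in place of 2-chlorophenyl on a saturated chain carbon bound to a sulfur. Within the data shown here, the one step that bears on this change is the move of the chlorine on the same benzyl ring between compound 1 and compound 2, and that step stayed within the scatter. On that basis the change to compound 3 is expected to give a step of a number 5.2 percentage points lower from compound 1 to compound 3 (within the scatter), with no movement beyond the scatter foreseen in either direction. Compound 3 is therefore estimated at 18% in this assay, with a range from 4% to 32%.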

Compound 3, a percentage reported as inhibition, in the whole organism at one dose (the size of the read-out at that dose, not a potency): 22.2%
The estimate for compound 3 lay 4.2 percentage points below the measured number; the measured number falls inside the stated range.
By their numbers in this assay, from the lowest: compounds 2, 3 and 1 (each within the scatter of the next).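

In this assay, 4-chlorophenyl in place of 2-chlorophenyl gives a number 1 percentage points lower from compound 1 to compound 3 (within the scatter) and 4-chlorophenyl in place of 3-chlorophenyl gives a number 6.7 percentage points higher from compound 2 to compound 3 (within the scatter) in the same read-out. With these steps, all three chlorophenyl isomers on a saturated chain carbon bound to a sulfur can be compared, and moving the chlorine around this ring separates none of them beyond the scatter at this single oral dose. Nothing available explains why these compounds stay so close.

As far as these compounds go, it remains open whether a group other than chlorine on this ring, such as a methoxy group, a nitrile or an amine, would move the number beyond the scatter. Also open, from the compounds shown here alone, is what a longer chain on the sulfur would do, and whether the three isomers would stay this close at another dose.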